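Butyl for isopropyl on the amine nitrogen

This account rests on a few compounds, and the source may have more. Where it says the series, first, only, none or still open, it means among the compounds named here.

Of the compounds shown here, three sharing one core have been measured in a functional assay on the whole organism for inhibition, with Mus musculus as the target; a lower number here means that less compound is needed, a higher number that more compound is needed for the effect. Compound 1 `CCCCOC(=O)Nc1cccc2c1CN(C)CC2c1ccccc1` gives 4 mg/kg, compound 2 `CCNCC(=O)Nc1cccc2c1CN(C)CC2c1ccccc1` gives 47 mg/kg, and compound 3 `CC(C)NCC(=O)Nc1cccc2c1CN(C)CC2c1ccccc1` gives 14 mg/kg. Compound 3 therefore holds the middle of the three numbers, well clear of both neighbours.

Compound 4 `CCCCNCC(=O)Nc1cccc2c1CN(C)CC2c1ccccc1` has not yet been measured in this assay. It carries butyl in place of isopropyl on an amine nitrogen.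

The nearest evidence is a 3.4-fold lower number from compound 2 to compound 3 (0.53 log units; beyond the scatter), a modest step with methyl in place of hydrogen on the saturated chain carbon bound to the amine nitrogen. The steps of a 12-fold higher number from compound 1 to compound 2 (1.07 log units; beyond the scatter) and a 3.5-fold higher number from compound 1 to compound 3 (0.54 log units; beyond the scatter) bear only loosely, since each exchanges the whole butoxy group on the carbonyl carbon. A single step on this nitrogen sets no trend, and no unbranched chain longer than ethyl has been measured there. A small shift towards a lower number is expected, most likely not beyond the scatter. The expected step is a 1.4-fold lower number from compound 3 to compound 4 (0.15 log units; within the scatter).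

For compound 4 the estimate is 10 mg/kg, with an expected range of 3.5 mg/kg to 30 mg/kg.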

Compound 4, dose for half-maximal effect: 32 mg/kg
The estimate for compound 4 lay 3.2-fold (0.51 log units) below the measured number; measured number outside the range, above it.
By their numbers in this assay, from the lowest: compound 1; then compound 3; then compounds 4 and 2 (each within the scatter of the next).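

In this assay, butyl on the amine nitrogen gives up what isopropyl had gained, with a 2.3-fold higher number from compound 3 to compound 4 (0.36 log units; beyond the scatter) as the step, while the comparison with the ethyl-bearing amine gives a 1.5-fold lower number from compound 2 to compound 4 (0.17 log units; within the scatter) and so separates butyl from ethyl by no more than the scatter; among these three amines, isopropyl alone stands apart, and a longer unbranched chain on this nitrogen brings no gain over ethyl. The butyl-bearing amine also stays well short of the butoxy carbamate, with an 8.0-fold higher number from compound 1 to compound 4 (0.90 log units; beyond the scatter) as the step, so all three amines now have numbers beyond the scatter above that of compound 1, and a butyl group at the far end of the side chain does not restore the number seen with butoxy. Nothing at hand explains why isopropyl and butyl differ on this nitrogen.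

Open, on these data alone, is whether another branched or cyclic group on the amine nitrogen, such as tert-butyl or cyclopentyl, would stand with isopropyl or with ethyl and butyl. Also open, as far as these compounds go, is whether a longer chain such as hexyl, or a cyclic amine such as piperidine in place of the secondary amine, would move the number in either direction.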